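Tolyl and chlorophenyl sulfonate cyanoacrylamides on leukemia cells

A few compounds are considered here, and "the series" means these few. Any claim that something is new, unique, unknown or untested is made for them only; others in the source may bear on it.

Compound 1 `Cc1ccc(S(=O)(=O)Oc2ccccc2/C=C(\C#N)C(=O)Nc2nnc(Cc3cccc4ccccc34)s2)cc1` and compound 2 `N#C/C(=C\c1ccccc1OS(=O)(=O)c1ccc(Cl)cc1)C(=O)Nc1nnc(Cc2cccc3ccccc23)s1` share a core and differ in one place. In a functional assay on RS4-11 cells (Homo sapiens) for inhibition, read by CCK-8 assay, with a stated time of 48 h, tested at 20 uM (on this read-out lower numbers stand for less inhibition of growth and higher numbers for more inhibition of growth at the one concentration tested), compound 1 gives 73% and compound 2 gives 68%. The change from compound 2 to compound 1 is methyl in place of chloro on an aromatic carbon and it made a number 5 percentage points higher from compound 2 to compound 1 (within the scatter).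

Compound 3 `Cc1ccc(S(=O)(=O)Oc2ccccc2/C=C(\C#N)C(=O)Nc2nnc(Cc3ccc(Cl)cc3)s2)cc1` gives 69% in this assay; the change from compound 1 to compound 3 made a number 4 percentage points lower from compound 1 to compound 3 (within the scatter). The difference between the cores of compound 2 and compound 3 is not broken down here; their values are within the scatter of each other.

Compound 4 `Cc1ccc(Cc2nnc(NC(=O)/C(C#N)=C/c3ccccc3OS(=O)(=O)c3ccc(C)cc3)s2)cc1` has not yet been tested. It differs from compound 3 by methyl in place of chloro on an aromatic carbon. The place is the same as in the step from compound 2 to compound 1, while the wider reading differs: 4-chlorobenzyl to 4-methylbenzyl here, (4-chlorophenyl)sulfonyl to (4-methylphenyl)sulfonyl there. The step from compound 3 to compound 4 is expected to be a number 3 percentage points higher from compound 3 to compound 4 (within the scatter) in this assay, resting on the step from compound 2 to compound 1 of a number 5 percentage points higher from compound 2 to compound 1 (within the scatter). For compound 4 the estimate is 72%, with a range from 62% to 82%.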

Compound 4, percent growth inhibition at one concentration: 66%
Beside the measured number, compound 4's estimate is 6 percentage points above it; measured number inside the range.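

In this assay, methyl in place of chloro, read as 4-chlorobenzyl to 4-methylbenzyl, gives a number 3 percentage points lower from compound 3 to compound 4 (within the scatter), and 4-methylphenyl in place of naphthalen-1-yl gives a number 7 percentage points lower from compound 1 to compound 4 (within the scatter). Set beside the same exchange on the (4-chlorophenyl)sulfonyl group, the two readings of methyl in place of chloro do not differ: the same change on two cores in this assay, a number 5 percentage points higher (within the scatter) from compound 2 to compound 1 and a number 3 percentage points lower (within the scatter) from compound 3 to compound 4, 8 percentage points apart, within the scatter of two such steps

This shows no sign that the change acts differently from one core to the other, but it does not show that any effect carries over, since each of the two steps is itself within the scatter and the change has no effect here that can be told from that scatter on either core.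

Open, going by these compounds, is whether a group other than methyl or chloro at this place, such as methoxy, an amine or a carboxylic acid, would move the number beyond the scatter. Equally open, on these data alone, is whether a longer chain in place of the saturated chain carbon that carries the aromatic group would do so.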